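Thiazolethione aryl swap: from dihydroxyphenyl to methoxyphenyl

A few compounds are considered here, and "the series" means these few. Any claim that something is new, unique, unknown or untested is made for them only; others in the source may bear on it.

Measured so far:
compound 1, `COc1cc(-n2c(-c3ccc(Cl)cc3)csc2=S)cc(OC)c1OC`, in a functional assay on MCF7 cells (Homo sapiens) for cytotoxicity, read by MTT assay, with a stated time of 48 h (on this read-out lower numbers stand for stronger inhibition and higher numbers for weaker inhibition), compound 1 gives > 100 ug/mL, which is a limit of the assay and not a number.
compound 2, `COc1cc(-n2c(-c3ccc(O)c(O)c3)csc2=S)cc(OC)c1OC`, in this assay compound 2 gives > 100 ug/mL, again a limit and not a number.

For the measured compounds named here, compound 2 therefore stands at the limit, and so does its one neighbour; both values shown sit there (the limit of > 100 ug/mL in this assay, at which 2 of the 2 values shown sit). Going by the values given here, the only measured step, a step that the two limits leave unreadable from compound 1 to compound 2, is thus unreadable in size. Compound 3, `COc1ccc(-c2csc(=S)n2-c2cc(OC)c(OC)c(OC)c2)cc1`, differs from compound 2 in one place: 4-methoxyphenyl in place of 3,4-dihydroxyphenyl on an aromatic carbon. Among the compounds with values here, no measured step gives a readable size for such a swap on this core, since the step from compound 1 to compound 2 lies between two limits. The expectation is therefore that compound 3 shows no movement beyond the scatter and most likely also sits at the limit in this assay. Compound 3 is estimated at 200 ug/mL, with a range from 60 ug/mL to 700 ug/mL, which as a step means a step that the limit leaves unreadable from compound 2 to compound 3 expected.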

Compound 3, half-maximal inhibitory concentration: > 100 ug/mL
Compound 3: a limit, no number; the forecaster's own chance of this, stated with the estimate: 75%; the middle value is on the limit's open side.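

For the compounds shown here, compound 3, like compound 1 and compound 2, gives a limit and not a number, so no step among the three can be read: the limit of > 100 ug/mL in this assay, at which 3 of the 3 values shown sit. The compounds shown leave open how far these swaps on the shared core change the read-out in this assay.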